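Trifluoromethyl to nitro on an aromatic carbon

The compounds below may be only part of what the source reports. "The series", "measured", "known", "first", "only" and "open" are said of these compounds alone.

Measured so far:
Compound 1 `Cc1ccc(CO/N=C/c2c(C)nn(C)c2Oc2ccc(Cl)cc2)cc1`: 30.4%
Compound 2 `CCOC(=O)c1ccc(CO/N=C/c2c(C)nn(C)c2Oc2ccc(Cl)cc2)cc1`: 20.9%
Compound 3 `Cc1nn(C)c(Oc2ccc(Cl)cc2)c1/C=N/OCc1ccc(C(F)(F)F)cc1`: 27.6%

In a functional assay on MKN-45 cells (Homo sapiens) for antiproliferative activity, tested at 1 uM (on this read-out higher numbers stand for more inhibition at the one concentration tested (going by the name of the read-out) and lower numbers for less inhibition), compound 3 gives 27.6%, the second highest of the three numbers. Its neighbours sit close: a number 2.8 percentage points lower from compound 1 to compound 3 (within the scatter) and a number 6.7 percentage points higher from compound 2 to compound 3 (within the scatter), so the three compounds cannot be told apart on this read-out.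

Compound 4 `Cc1nn(C)c(Oc2ccc(Cl)cc2)c1/C=N/OCc1ccc([N+](=O)[O-])cc1` differs from compound 3 in one place: nitro in place of trifluoromethyl on an aromatic carbon. Going by the values given here, the steps that bear on this change are the earlier swaps at the same aromatic carbon: a number 9.5 percentage points lower from compound 1 to compound 2 (within the scatter), a number 2.8 percentage points lower from compound 1 to compound 3 (within the scatter) and a number 6.7 percentage points higher from compound 2 to compound 3 (within the scatter). Among the compounds with values here, all three are within the scatter, and none of them involves nitro, so there is no direct precedent for this group. Since every swap so far at this position has left the number essentially unchanged, compound 4 is expected to stay in the same band, with an estimated step of a number 1.6 percentage points lower from compound 3 to compound 4 (within the scatter). Compound 4 is therefore estimated at 26%, with a range from 12% to 40%.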

Compound 4, a percentage reported as inhibition, at one concentration (the size of the read-out at that concentration, not a potency): 24.6%
For compound 4 the middle estimate is 1.4 percentage points above the measured one, and the stated range covers the measured number.
By their numbers in this assay, from the lowest: compounds 2, 4, 3 and 1 (each within the scatter of the next).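

Nitro now stands as a fourth group on this aromatic carbon, para to a large group, and the number in this assay still does not separate it from the other three: there is a number 3 percentage points lower from compound 3 to compound 4 (within the scatter) and a number 3.7 percentage points higher from compound 2 to compound 4 (within the scatter) and a number 5.8 percentage points lower from compound 1 to compound 4 (within the scatter). Trifluoromethyl, ethoxycarbonyl, methyl and nitro therefore cannot be told apart at this position on this read-out, so the change from trifluoromethyl to nitro has no visible effect here. Nothing measured here offers an explanation for how closely these numbers sit.

Still open, on these data alone, is whether an amine or a carboxylic acid on this carbon would give a step beyond the scatter. Because each number comes from a single concentration, the read-out also leaves open how these compounds compare in potency.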